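Cytotoxicity notes on the step to compound 3

The source may hold more compounds than are shown below. What is called first, only, known or untested is meant among the compounds shown, and "the series" means these compounds.

Values in an ADME assay on MDBK cells (Bos taurus) for cytotoxicity, read by MTT assay (a higher number here means that more compound is tolerated, a lower number that less compound is tolerated), so far:
- compound 1 `COc1ccc(OCCCCCCN2C[C@H](O)[C@@H](O)[C@H](O)[C@H]2CO)cc1` gives > 500000 nM (a limit of the assay, not a number)
- compound 2 `CC1CC(OCCCCCCN2C[C@H](O)[C@@H](O)[C@H](O)[C@H]2CO)CC(C)(C)C1` gives 250000 nM (the only actual number)

Among the compounds with values here, compound 3 `CC1CCCC(OCCCCCCN2C[C@H](O)[C@@H](O)[C@H](O)[C@H]2CO)C1C` has a group of 8 heavy atoms (8 carbon; one six-membered non-aromatic ring of carbon only) in place of a group of 9 heavy atoms (9 carbon; one six-membered non-aromatic ring of carbon only), on an oxygen on a saturated carbon as its single change from compound 2. Within the data shown here, the only measured step is an at least 2.0-fold lower number from compound 1 to compound 2 (0.30 log units; that floor lies within the scatter) and it concerns a different replacement, so it offers a weak guide. With compound 2 at 250000 nM as the anchor and a six-membered non-aromatic ring of carbon only on both sides of the change, no step beyond the scatter is expected in this assay here. The expected step is a 1.1-fold higher number from compound 2 to compound 3 (0.05 log units; within the scatter) as estimated. The estimated value for compound 3 is 280000 nM with an expected range from 150000 nM to 500000 nM for now.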

Compound 3, half-maximal cytotoxic concentration: > 500000 nM
Compound 3: a limit, no number; the forecaster's own chance of this, stated with the estimate: 20%; at least 1.7-fold (0.25 log units) between middle value and limit.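

In this assay, the change on an oxygen on a saturated carbon gives an at least 2.0-fold higher number from compound 2 to compound 3 (0.30 log units; that floor lies within the scatter), so the floor alone does not separate these two six-membered carbon rings. The value of compound 3 is a limit of the assay, not a number, and the steps to it from compound 1 cannot be read. Compound 2 remains the only compound with an actual number: the limit of > 500000 nM in this assay, at which 2 of the 3 values shown sit.

From the compounds shown here alone, how far compound 3 lies past its limit remains open. So does the effect of an amine on the ring or a longer chain to the shared core.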